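Moving a fluoro group from compound 3 to compound 4

The source may report more compounds than this note shows. Statements on the series, on what has been measured and on what is new or still open speak of the compounds shown alone.

Measured in a functional assay on HepG2 cells (Homo sapiens) for cytotoxicity, read by MTT assay, with a stated time of 48 h; a higher number here means a weaker inhibitor, a lower number a stronger inhibitor:
- compound 1 `Cc1ncc([N+](=O)[O-])n1CCSc1nnc(-c2ccccc2)o1`: 17500 nM
- compound 2 `CCOc1ccc(-c2nnc(SCCn3c([N+](=O)[O-])cnc3C)o2)cc1`: 1900 nM
- compound 3 `Cc1ncc([N+](=O)[O-])n1CCSc1nnc(-c2ccccc2F)o1`: 3700 nM

A lower number here marks the stronger inhibitor of cell growth. Compound 3, at 3700 nM, cannot be told apart from compound 2, at 1900 nM, since the two values lie within the usual scatter of each other. Both sit well under the number for the unsubstituted compound 1.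

The next compound is compound 4 `Cc1ncc([N+](=O)[O-])n1CCSc1nnc(-c2ccc(F)cc2)o1`. It carries 4-fluorophenyl in place of 2-fluorophenyl on an aromatic carbon. The same atoms are kept, joined differently.

Going by the values given here, two measured steps bear on this change. Adding fluoro gave a 4.7-fold lower number from compound 1 to compound 3 (0.67 log units; beyond the scatter), and adding ethoxy gave a 9.2-fold lower number from compound 1 to compound 2 (0.96 log units; beyond the scatter). Both are modest but beyond the scatter, and both show that a group added to the bare aromatic ring lowered the number. Neither step moves a group from one ring position to another, so the data give no measured size for such a move. The fluoro group stays in compound 4, so no step beyond the scatter is expected in this assay, in either direction.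

The expected step is a 1.1-fold higher number from compound 3 to compound 4 (0.03 log units; within the scatter). For compound 4 the estimated value is 4000 nM, with an expected range from 1600 nM to 11000 nM.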

Compound 4, half-maximal inhibitory concentration: 600 nM
Compound 4: middle estimate off by 6.7-fold (0.82 log units), on the high side, and the stated range ends above it.
By their numbers in this assay, from the lowest: compound 4; then compounds 2 and 3 (each within the scatter of the next); then compound 1.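

In this assay, going by these compounds alone, the place of the fluoro group on the phenyl ring matters: 4-fluorophenyl in place of 2-fluorophenyl gives a 6.2-fold lower number from compound 3 to compound 4 (0.79 log units; beyond the scatter) and thus a change beyond the scatter with no atom gained or lost, something the earlier steps could not show, as each of them added a group to the bare ring. Within the data shown here, the fluoro group in 4-fluorophenyl also compares well with the ethoxy group, with a 3.2-fold lower number from compound 2 to compound 4 (0.50 log units; beyond the scatter) for that exchange, and the full change from the bare phenyl ring is a 29-fold lower number from compound 1 to compound 4 (1.46 log units; beyond the scatter) and the only step here rated large. Nothing measured here gives a reason for this effect of position.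

From the compounds shown here alone, whether a chloro group or a nitrile in place of the fluoro group in 4-fluorophenyl would keep the number this low remains open. Also open, going by these compounds, is whether moving the ethoxy group around its ring would shift the number as moving the fluoro group did.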